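The compounds below may be only part of what the source reports. "The series", "measured", "known", "first", "only" and "open" are said of these compounds alone.

Working notes on the thiosemicarbazone series.

Going by the values given here, compound 1 `CC1=CC[C@H](C(C)(C)NC(=S)N/N=C/c2ccccc2O)CC1` gives 3700 nM in a functional assay on NCI/ADR-RES cells (Homo sapiens) for inhibition, read by sulforhodamine B assay, with a stated time of 48 h (a lower number here means a stronger inhibitor of growth, a higher number a weaker inhibitor of growth), the lowest of the three numbers so far. Compound 3 `CC1=CC[C@H](C(C)(C)NC(=S)N/N=C/c2ccccc2[N+](=O)[O-])CC1` sits nearest to it with 19200 nM, and compound 2 `COc1cc(/C=N/NC(=S)NC(C)(C)[C@H]2CC=C(C)CC2)ccc1O` is furthest with 23900 nM; compound 2 differs from compound 1 in more than one place, so its gap is only noted, not read as a single step.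

Among the compounds with values here, the one measured step that changes the aryl group alone is a 5.2-fold higher number from compound 1 to compound 3 (0.72 log units; beyond the scatter), which already shows that touching the hydroxyphenyl end of compound 1 raises the number well beyond the scatter.

Compound 4 `CC1=CC[C@H](C(C)(C)NC(=S)N/N=C/c2ccc[nH]2)CC1` has not been measured. Relative to compound 1 the difference is 1H-pyrrol-2-yl in place of 2-hydroxyphenyl on a carbon with a double bond to nitrogen. The change is larger than the step from compound 1 to compound 3, since both the hydroxy and the six-membered ring leave; the entering pyrrole keeps one hydrogen-bond donor but brings no acceptor. The step from compound 1 to compound 3 is therefore taken as the nearest guide, and a rise of similar size in this assay is expected, with the range kept wide because no other ring replacement on this end has been measured.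

For compound 4 the estimate in this assay is 12000 nM, between 3500 nM and 40000 nM, which means an expected step of a 3.2-fold higher number from compound 1 to compound 4 (0.51 log units; beyond the scatter).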

Compound 4, concentration for 50% growth inhibition: 78000 nM
For compound 4 the middle estimate is 6.5-fold (0.81 log units) below the measured one; measured number outside the range, above it.
By their numbers in this assay, from the lowest: compound 1; then compounds 3 and 2 (each within the scatter of the next); then compound 4.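

Replacing the whole aryl group costs more than changing its substituent: in this assay, the step is a 21-fold higher number from compound 1 to compound 4 (1.32 log units; beyond the scatter), against a 5.2-fold higher number from compound 1 to compound 3 (0.72 log units; beyond the scatter) for nitro in place of hydroxy on the aromatic carbon. Compound 4 keeps the count of one hydrogen-bond donor on this end, yet its number still rises, so in this single pair that count alone does not hold the value of compound 1; the loss of the hydrogen-bond acceptor and the move from a six-membered to a five-membered aromatic ring travel together in the same step. No line of measured evidence bears on what lies behind this rise.

The step from 2-hydroxyphenyl to 1H-pyrrol-2-yl changes ring size, hetero atom and hydroxy at once, so the share of each stays unresolved in the compounds shown. On these data alone, a plain phenyl or an aminophenyl group on the carbon with a double bond to nitrogen would separate these parts, and whether any ring on this end can match compound 1 remains open.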